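Swapping the Aryl Group on a Sulfonyl Sulfur

The compounds below may be only part of what the source reports. "The series", "measured", "known", "first", "only" and "open" are said of these compounds alone.

Within the data shown here, in a functional assay on HEK293 cells (Homo sapiens) for cytotoxicity (a lower number here means that less compound is tolerated, a higher number that more compound is tolerated), compound 3 (`COc1ccc(OC)c(S(=O)(=O)Nc2cccc(N3C[C@@H](c4ccc(OC)c(OC5CCCC5)c4)CC3=O)c2)c1`) gives 7590 nM, the only actual number among the three compounds measured so far. Compound 1 (`COc1ccc([C@H]2CC(=O)N(c3cccc(C#N)c3)C2)cc1OC1CCCC1`) returns only a limit, > 10000 nM. Compound 2 (`CCCCNc1cccc(N2C[C@@H](c3ccc(OC)c(OC4CCCC4)c3)CC2=O)c1`) likewise returns only a limit, > 10000 nM. The picture so far is therefore dominated by the limit of > 10000 nM in this assay, at which 2 of the 3 values shown sit.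

Compound 4 (`COc1ccc([C@H]2CC(=O)N(c3cccc(NS(=O)(=O)c4cccc(Cl)c4C)c3)C2)cc1OC1CCCC1`) differs from compound 3 at a single place, with 3-chloro-2-methylphenyl in place of 2,5-dimethoxyphenyl on a sulfonyl sulfur.

Among the measured compounds shown here, the only measured step is a step that the two limits leave unreadable from compound 1 to compound 2. It involves butylamino in place of cyano on an aromatic carbon, which is a different change from the one made here, and it gives no size to scale from. For the measured compounds named here, no measured step involves a change of the group on the sulfonyl sulfur. Without such a step, no shift beyond the scatter in either direction is expected in this assay. The expected size is a 1.1-fold lower number from compound 3 to compound 4 (0.04 log units; within the scatter). For compound 4 the estimated value is 7000 nM, with an expected range of 3000 nM to 14000 nM.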

Compound 4, half-maximal cytotoxic concentration: > 10000 nM
Compound 4: only a limit was reported (the forecaster's own chance of this, stated with the estimate: 35%); middle value at least 1.4-fold (0.15 log units) from the limit.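

Among these compounds, exchanging 2,5-dimethoxyphenyl for 3-chloro-2-methylphenyl on the sulfonyl sulfur gives an at least 1.3-fold higher number from compound 3 to compound 4 (0.11 log units; that floor lies within the scatter), the first step with a readable direction, although it does not establish a shift beyond the scatter. Among the compounds shown here, it also shows that the sulfonamide nitrogen and sulfonyl sulfur do not, on their own, bring a compound to an actual number in this assay: compound 3, with 2,5-dimethoxyphenyl, remains the only compound that has one, while compound 4, with 3-chloro-2-methylphenyl, returns only a limit. The steps linking compound 4 to compound 1 and compound 2 cannot be read, and the series now gathers at a single point: the limit of > 10000 nM in this assay, at which 3 of the 4 values shown sit.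

The compounds shown do not separate the chlorine from the methyl of the entering group, nor one methoxy group of the leaving group from the other, so the part of the exchange that carries the step stays open. They also do not tell how the read-out would respond to a pyridine ring, an unsubstituted phenyl or a simple methyl on the sulfonyl sulfur.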